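Sulfanyl in place of the oxidised pyridylmethyl group

The source may report more compounds than this note shows. Statements on the series, on what has been measured and on what is new or still open speak of the compounds shown alone.

Measured so far in a functional assay on HCC827 cells (Homo sapiens) for antiproliferative activity, read by MTT assay, with a stated time of 72 h; on this read-out higher numbers stand for weaker inhibition and lower numbers for stronger inhibition
compound 1 `CN1CCN(c2ccc(Nc3ncc4nc(Sc5ccccc5)n(C5CCOCC5)c4n3)cc2)CC1` gives 42.6 nM
compound 2 `CN1CCN(c2ccc(Nc3ncc4nc(SCc5ccccc5)n(C5CCOCC5)c4n3)cc2)CC1` gives 107 nM
compound 3 `CN1CCN(c2ccc(Nc3ncc4nc([S+]([O-])Cc5cccnc5)n(C5CCOCC5)c4n3)cc2)CC1` gives > 10000 nM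

Compound 3 with > 10000 nM stands at a limit and not at a number. Compound 4 `CN1CCN(c2ccc(Nc3ncc4nc(SCc5cccnc5)n(C5CCOCC5)c4n3)cc2)CC1` differs from compound 3 by a group of 8 heavy atoms (6 carbon, 1 nitrogen, 1 sulfur; one six-membered aromatic ring with 1 hetero atom) in place of a group of 9 heavy atoms (6 carbon, 1 nitrogen, 1 oxygen, 1 sulfur; one six-membered aromatic ring with 1 hetero atom), on an aromatic carbon and the group entering is ((pyridin-3-yl)methyl)sulfanyl, on the same aromatic carbon of the five-membered ring. The large step of an at least 93-fold higher number from compound 2 to compound 3 (1.97 log units; beyond the scatter) ends at the group that leaves here, and so does the large step of an at least 230-fold higher number from compound 1 to compound 3 (2.37 log units; beyond the scatter) from the other side. The step of a 2.5-fold higher number from compound 1 to compound 2 (0.40 log units; beyond the scatter) is modest by comparison and stays among compounds with a plain sulfanyl link, which compound 4 also carries. Most of an at least 93-fold higher number from compound 2 to compound 3 (1.97 log units; beyond the scatter) is therefore expected to be undone, with compound 4 landing close to the range of compound 2 at 107 nM and giving a real number. The step expected here is an at least 66-fold lower number from compound 3 to compound 4 (1.82 log units; beyond the scatter) and it is a large one towards stronger inhibition. Compound 4 is estimated at 150 nM with 40 nM to 600 nM as its expected range.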

Compound 4, half-maximal inhibitory concentration: 500 nM
Compound 4: middle estimate off by 3.3-fold (0.52 log units), on the low side; the measured number falls inside the stated range.
By their numbers in this assay, from the lowest: compound 1; then compound 2; then compound 4. At a limit, above all of these: compound 3.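

In this assay, the ((pyridin-3-yl)methyl)sulfanyl group on this aromatic carbon gives an at least 20-fold lower number from compound 3 to compound 4 (1.30 log units; beyond the scatter), so a plain sulfanyl link with this pyridine ring keeps a real value, which the oxidised compound did not show. Pyridin-3-yl in place of phenyl on the same link is now read apart from the oxidation, as a 4.7-fold higher number from compound 2 to compound 4 (0.67 log units; beyond the scatter), so the ring change alone carries a modest part of the loss seen in compound 3. Against the phenylsulfanyl compound, the combined change of ring and link gives a 12-fold higher number from compound 1 to compound 4 (1.07 log units; beyond the scatter).

From the compounds shown here alone, the full size of the oxidation step stays open, with compound 3 standing at a limit and not at a number: the limit of > 10000 nM in this assay, at which 1 of the 4 values shown sits. Also open, going by these compounds, is how a pyridin-4-yl group, or a benzyl ring carrying an amine, would read on the same sulfanyl link.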